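Notes on a methoxy-to-hydrogen change in this series

This account rests on a few compounds, and the source may have more. Where it says the series, first, only, none or still open, it means among the compounds named here.

Measured so far, in a functional assay on SW480 cells (Homo sapiens) for cytotoxicity, read by sulforhodamine B assay, with a stated time of 48 h; a higher number here means a weaker inhibitor, a lower number a stronger inhibitor:
compound 1 `COc1cccc(/C=C/C(=O)c2cccc(-c3cccc(F)c3)c2)c1OC` gives 13500 nM
compound 2 `COc1ccccc1/C=C/C(=O)c1cccc(-c2cccc(F)c2)c1` gives 16600 nM
compound 3 `COc1cc(/C=C/C(=O)c2ccc(N)c(-c3ccc(F)cc3)c2)cc(OC)c1OC` gives 6120 nM

Compound 1 and compound 2 differ in one place: hydrogen in place of methoxy on an aromatic carbon. The step of a 1.2-fold higher number from compound 1 to compound 2 (0.09 log units; within the scatter). Compound 3 is built on a different core; how compound 3 differs from compound 1 is not broken down here, and its value simply stands as the lowest of the three.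

Compound 4 `COc1ccc(/C=C/C(=O)c2ccc(N)c(-c3ccc(F)cc3)c2)cc1OC` awaits measurement. It differs from compound 3 by hydrogen in place of methoxy on an aromatic carbon. The surroundings are not identical to those in compound 1: in compound 4 the site is also meta to a methoxy group, so this is the same kind of change, not the same one.

The step from compound 3 to compound 4 is expected to be small, a 1.1-fold higher number from compound 3 to compound 4 (0.06 log units; within the scatter), resting on a 1.2-fold higher number from compound 1 to compound 2 (0.09 log units; within the scatter). Compound 4 is accordingly estimated at 7000 nM, between 3500 nM and 14000 nM.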

Compound 4, half-maximal inhibitory concentration: 6640 nM
For compound 4 the middle estimate is 1.1-fold (0.02 log units) above the measured one, within the range that was stated.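

In this assay, hydrogen in place of methoxy on an aromatic carbon gives a 1.1-fold higher number from compound 3 to compound 4 (0.04 log units; within the scatter). Set beside the earlier case, the two steps agree: the same change on two cores in this assay, a 1.2-fold higher number (0.09 log units; within the scatter) from compound 1 to compound 2 and a 1.1-fold higher number (0.04 log units; within the scatter) from compound 3 to compound 4, 1.1-fold (0.05 log units) apart, within the scatter of two such steps. For these two pairs, the change carries from one core to the other without a discernible shift in the read-out, but neither step can be told from scatter, so this does not show that the result would hold at other sites or on other cores.

The compounds shown leave open what a replacement other than hydrogen would do at this site, such as a hydroxy group, an ethoxy group or a chlorine atom. Also open, as far as these compounds go, is whether a carboxylic acid there would behave alike on both cores.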